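Ring Size Change on the Amide Side Chain

The source may report more compounds than this note shows. Statements on the series, on what has been measured and on what is new or still open speak of the compounds shown alone.

Compound 3 `COc1cc2ncnc(N3CCc4ccccc43)c2cc1NC(=O)/C=C/CN1CCCC1`: 1510 nM
Compound 2 `CC/C=C/C(=O)Nc1cc2c(N3CCc4ccccc43)ncnc2cc1OC`: 4030 nM
Compound 1 `COc1cc2ncnc(N3CCc4ccccc43)c2cc1NC(=O)C=C(C)C`: 6390 nM

In a functional assay on MCF7 cells (Homo sapiens) for antiproliferative activity, read by MTT assay, with a stated time of 72 h (on this read-out higher numbers stand for weaker inhibition and lower numbers for stronger inhibition), compound 3 gives the lowest number of the three, with a 2.7-fold lower number from compound 2 to compound 3 (0.43 log units; beyond the scatter) and a 4.2-fold lower number from compound 1 to compound 3 (0.63 log units; beyond the scatter) both beyond the scatter. Compound 4 `COc1cc2ncnc(N3CCc4ccccc43)c2cc1NC(=O)/C=C/CN1CCCCC1` differs from it only by piperidin-1-yl in place of pyrrolidin-1-yl on a saturated chain carbon bound to a double-bonded chain carbon. Within the data shown here, no measured step changes one of these rings for another; the steps that exist swap a methyl or a small chain for the pyrrolidine ring, and they are only modest. A change of ring size with the same kind of nitrogen kept in place is expected to move the number little, if at all, beyond the scatter. Compound 4 is therefore estimated at 1400 nM (range 550 nM to 3600 nM), a step of a 1.1-fold lower number from compound 3 to compound 4 (0.03 log units; within the scatter) expected from compound 3.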

Compound 4, half-maximal inhibitory concentration: 1680 nM
Estimate against measurement, compound 4: 1.2-fold (0.08 log units) below, and the stated range covers the measured number.
By their numbers in this assay, from the lowest: compounds 3 and 4 (each within the scatter of the next); then compounds 2 and 1 (each within the scatter of the next).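

In this assay the larger piperidin-1-yl ring in place of pyrrolidin-1-yl gives a 1.1-fold higher number from compound 3 to compound 4 (0.05 log units; within the scatter) and so does not separate the two compounds, which shows that this position tolerates either ring size. The piperidine compound also keeps the advantage over the ring-free side chains, with a 2.4-fold lower number from compound 2 to compound 4 (0.38 log units; beyond the scatter) and a 3.8-fold lower number from compound 1 to compound 4 (0.58 log units; beyond the scatter) as the two steps. Nothing measured here explains these results. Still open, on these data alone, is whether morpholine, 4-methylpiperazine or open-chain dimethylamino would read alike on this saturated chain carbon.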